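Moving fluorine on the phenyl of compound 3

This account rests on a few compounds, and the source may have more. Where it says the series, first, only, none or still open, it means among the compounds named here.

Of the compounds shown here, three sharing one core have been tested in a functional assay on PC-3 cells (Homo sapiens) for antiproliferative activity, read by MTT assay, tested at 1 uM; on this read-out higher numbers stand for a stronger effect at the one concentration tested and lower numbers for a weaker effect. Compound 1 `COc1cc(C2=NN(C(C)=O)C(c3cccc(OC)c3OC)O2)cc(OC)c1OC` gives 35%, compound 2 `COc1ccc(C2OC(c3cc(OC)c(OC)c(OC)c3)=NN2C(C)=O)c(OC)c1` gives 69.5%, and compound 3 `COc1cc(C2=NN(C(C)=O)C(c3ccc(F)cc3)O2)cc(OC)c1OC` gives 0%. Compound 3 thus stands lowest of the three: the step of a number 35 percentage points lower from compound 1 to compound 3 (beyond the scatter) and the step of a number 69.5 percentage points lower from compound 2 to compound 3 (beyond the scatter) both lie beyond the scatter.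

Compound 4 `COc1cc(C2=NN(C(C)=O)C(c3cccc(F)c3)O2)cc(OC)c1OC` is not yet measured. The change from compound 3 is 3-fluorophenyl in place of 4-fluorophenyl on a saturated ring carbon on a saturated ring carbon. Within the data shown here, no measured step moves a fluorine from one spot on that phenyl to another. The nearest guide is a number 34.5 percentage points higher from compound 1 to compound 2 (beyond the scatter), where shifting one methoxy group on the same phenyl was enough to change this assay by a large amount; the two fluorophenyl compounds 3 and 4 may or may not behave alike. Given the near-zero start, a modest rise is expected for compound 4, estimated as a number 10 percentage points higher from compound 3 to compound 4 (within the scatter), giving compound 4 an expected value of 10% with a range from 0% to 35%.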

Compound 4, a percentage reported as inhibition, at one concentration (the size of the read-out at that concentration, not a potency): 16.5%
Beside the measured number, compound 4's estimate is 6.5 percentage points below it; low and high end bracket the measured number.
By their numbers in this assay, from the lowest: compound 3; then compound 4; then compound 1; then compound 2.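

Moving the fluorine alone gives a number 16.5 percentage points higher from compound 3 to compound 4 (beyond the scatter) in this assay, so this position responds to where one fluorine sits on the phenyl, even though the two groups have the same atoms, joined differently. Among these compounds, until now, the only change of placement on this phenyl involved methoxy groups, so this extends that sensitivity to a single fluorine. The 3-fluorophenyl group still falls short of both dimethoxyphenyl groups, with a number 18.5 percentage points lower from compound 1 to compound 4 (beyond the scatter) and a number 53 percentage points lower from compound 2 to compound 4 (beyond the scatter) on exchanging them, and among these four compounds both fluorophenyl compounds sit under both dimethoxyphenyl compounds.

Nothing available explains why the place of the fluorine matters here. Also open, on these data alone, is how this position would respond to a different kind of group on the phenyl, such as an amine or a carboxylic acid.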